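The source may report more compounds than this note shows. Statements on the series, on what has been measured and on what is new or still open speak of the compounds shown alone.

Compound 1 `Oc1cccc(-c2cc(-c3ccc(Cl)cc3)nc(-c3ccco3)c2)c1` is one of three closely related compounds tested in a functional assay on HCT-15 cells (Homo sapiens) for cytotoxicity, read by CCK-8 assay and cell counting, with a stated time of 2 days (a lower number here means a stronger inhibitor, a higher number a weaker inhibitor), and in that test compound 1 gives 10200 nM. Its two companions keep the whole shared core and the 4-chlorophenyl group and vary only the furan-2-yl group. Compound 2 `Oc1cccc(-c2cc(-c3ccc(Cl)cc3)nc(-c3ccsc3)c2)c1` carries a thiophen-3-yl group there, and in this assay compound 2 gives 8850 nM. Compound 3 `Oc1cccc(-c2cc(-c3ccc(Cl)cc3)nc(-c3cccnc3)c2)c1` carries a pyridin-3-yl group, and in this assay compound 3 gives 16800 nM. Among these three numbers compound 1 holds the second highest, but the nearest step, a 1.2-fold lower number from compound 1 to compound 2 (0.06 log units; within the scatter), and the furthest, a 1.6-fold higher number from compound 1 to compound 3 (0.22 log units; within the scatter), both lie within the scatter, as does a 1.9-fold higher number from compound 2 to compound 3 (0.28 log units; within the scatter), so none of the three can be separated from the others.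

Compound 4 `Oc1cccc(-c2cc(-c3cccc(Cl)c3)nc(-c3ccco3)c2)c1` changes a different part of the molecule: 3-chlorophenyl in place of 4-chlorophenyl on an aromatic carbon. Going by the values given here, no measured step touches the chlorophenyl group, so there is no direct precedent for this move. What the measured steps do show is that swapping one small aromatic group for another on this core has so far left the number within the scatter each time. The expectation for compound 4 is therefore a step of a 1.0-fold lower number from compound 1 to compound 4 (0.01 log units; within the scatter), that is, no change beyond the scatter. Compound 4 is estimated at 10000 nM, within a range from 4000 nM to 25000 nM.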

Compound 4, half-maximal inhibitory concentration: 2460 nM
Compound 4: middle estimate off by 4.1-fold (0.61 log units), on the high side, and the stated range ends above it.
By their numbers in this assay, from the lowest: compound 4; then compounds 2, 1 and 3 (each within the scatter of the next).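

Moving the chlorine on the chlorophenyl group, so that 3-chlorophenyl stands in place of 4-chlorophenyl, gives in this assay a 4.1-fold lower number from compound 1 to compound 4 (0.62 log units; beyond the scatter) and is the first step in this set to lie beyond the scatter. The group that leaves and the group that enters have the same atoms and differ only in where the chlorine sits, so at this position, on an aromatic carbon next to the ring nitrogen, that placement alone is enough to shift the number, whereas replacing the furan-2-yl group with thiophen-3-yl or pyridin-3-yl left it within the scatter. The step is modest and rests on a single pair, and no measurement here accounts for why the placement of the chlorine matters.

From the compounds shown here alone, it remains open whether the same lower number would hold with thiophen-3-yl or pyridin-3-yl alongside the 3-chlorophenyl group. Going by these compounds, it is also open whether the chlorine itself is needed, or whether a methyl group, an amine or a carboxylic acid in its place on that phenyl ring would give a similar number.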